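A few compounds are considered here, and "the series" means these few. Any claim that something is new, unique, unknown or untested is made for them only; others in the source may bear on it.

Measured so far:
compound 1 `CC1(C)[C@H]2CC[C@]1(C)N(Cc1cn(-c3cccc(F)c3)nn1)C(=O)C2` — 530 nM
compound 2 `Cc1ccc(-n2cc(CN3C(=O)C[C@@H]4CC[C@@]3(C)C4(C)C)nn2)cc1` — 390 nM

Both numbers come from a functional assay on SGC-7901 cells (Homo sapiens) for inhibition, read by MTT assay, with a stated time of 24 h; on this read-out lower numbers stand for stronger inhibition and higher numbers for weaker inhibition. Of the two, the number for compound 1 is the higher, with compound 2 nearest; yet the step of a 1.4-fold lower number from compound 1 to compound 2 (0.13 log units; within the scatter) lies within the scatter, so the two compounds cannot be told apart on this read-out. That step swapped 4-methylphenyl in place of 3-fluorophenyl on an aromatic nitrogen.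

Compound 3 `CC1(C)[C@H]2CC[C@]1(C)N(Cc1cn(-c3cccc(O)c3)nn1)C(=O)C2` has not yet been measured. It differs from compound 1 in one place: hydroxy in place of fluoro on an aromatic carbon. Among the compounds with values here, no measured step covers this change directly; the only step that alters the same phenyl ring, a 1.4-fold lower number from compound 1 to compound 2 (0.13 log units; within the scatter), stayed within the scatter, so it gives little guidance. No step beyond the scatter is therefore expected in this assay, in either direction. For compound 3 the expected value is 600 nM, with a range from 250 nM to 1500 nM, which means an expected step of a 1.1-fold higher number from compound 1 to compound 3 (0.05 log units; within the scatter).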

Compound 3, half-maximal inhibitory concentration: 270 nM
Estimate against measurement, compound 3: 2.2-fold (0.35 log units) above, within the range that was stated.
By their numbers in this assay, from the lowest: compounds 3, 2 and 1 (each within the scatter of the next).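

Hydroxy in place of fluoro, on the carbon meta to a large group, gives a 2.0-fold lower number from compound 1 to compound 3 (0.29 log units; within the scatter) in this assay. This adds a hydrogen-bond donor and a hydrogen-bond acceptor to the phenyl ring, and the step still stays within the scatter, so this position tolerates the swap but the data show no real gain. The other new comparison, 3-hydroxyphenyl in place of 4-methylphenyl, gives a 1.4-fold lower number from compound 2 to compound 3 (0.16 log units; within the scatter), so the three aryl groups shown cannot be told apart on this read-out.

From the compounds shown here alone, whether an amine, a methoxy group or a carboxylic acid at this place would produce a step beyond the scatter remains open. No outside evidence bears on these numbers, so they offer no explanation for this result.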